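From methoxy to hydroxy: the step from compound 2 to compound 3

A few compounds are considered here, and "the series" means these few. Any claim that something is new, unique, unknown or untested is made for them only; others in the source may bear on it.

Among the compounds with values here, in a functional assay on UACC-257 cells (Homo sapiens) for cytotoxicity, read by sulforhodamine B assay, with a stated time of 48 h, tested at 1 uM (a lower number here means a stronger effect, a higher number a weaker effect of the compound at the concentration tested), two compounds have numbers so far. Compound 1 `Cc1cc(O)cc(-c2nn(CC#N)cc2-c2ccnc(-c3ccc(Oc4ccccc4)cc3)c2)c1` gives -7%. Compound 2 `COc1cc(C)cc(-c2nn(CC#N)cc2-c2ccnc(-c3ccc(N(C)C)cc3)c2)c1` gives 48%, the higher of the two, a gap beyond the usual scatter. Compound 3 `Cc1cc(O)cc(-c2nn(CC#N)cc2-c2ccnc(-c3ccc(N(C)C)cc3)c2)c1` is not yet measured; it differs from compound 2 in one place: hydrogen in place of methyl on an oxygen on an aromatic ring. Within the data shown here, no step between measured compounds changes only this methoxy to hydroxy, so the expectation rests on the two numbers alone. The step of a number 28 percentage points lower from compound 2 to compound 3 (beyond the scatter) is expected to move the number downward. Compound 3 is estimated at 20%, within -15% to 50%.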

Compound 3, a percentage reported as activity, at one concentration (the size of the read-out at that concentration, not a potency): 31%
Beside the measured number, compound 3's estimate is 11 percentage points below it; low and high end bracket the measured number.
By their numbers in this assay, from the lowest: compound 1; then compound 3; then compound 2.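

In this assay the change from methoxy to hydroxy brings a number 17 percentage points lower from compound 2 to compound 3 (beyond the scatter) and so strengthens the effect while the dimethylamino group stays in place. With the hydroxy group kept, dimethylamino in place of phenoxy gives a number 38 percentage points higher from compound 1 to compound 3 (beyond the scatter) and weakens the effect, so this large step shows that the other end of the molecule also matters. Nothing available explains either shift.
Still open, on these data alone, is whether an amine or an ethoxy group on this ring would behave like hydroxy or like methoxy. Also open, as far as these compounds go, is whether methoxy to hydroxy would give a similar step with phenoxy in place of dimethylamino.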